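Swapping the side ring of compound 2 for a pyridine

The source may report more compounds than this note shows. Statements on the series, on what has been measured and on what is new or still open speak of the compounds shown alone.

Of the compounds shown here, two have been measured in an ADME assay on the whole organism (strain CD-1) for pharmacokinetics, with Mus musculus as the target, at a dose of 10 mg/kg by the oral route; on this read-out lower numbers stand for lower exposure and higher numbers for higher exposure at the dose given. Compound 1, with the structure `CC/C(=C(/c1ccc(/C=C/C(=O)O)cc1)c1ccc2[nH]ncc2c1)c1ccccc1`, gives 5800 ng.h/mL in this assay. Compound 2, with the structure `CS(=O)(=O)c1ccc(/C(=C(\c2ccc(/C=C/C(=O)O)cc2)c2ccc3[nH]nc(F)c3c2)C2CCC2)c(Cl)c1`, gives 140 ng.h/mL in this assay, which is the lower of the two numbers, and the gap between compound 1 and compound 2 lies beyond the scatter of repeated measurements. The two compounds differ in several places at once, so no single change can be tied to that gap.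

Compound 3, with the structure `N#Cc1cc(Cl)cnc1/C(=C(\c1ccc(/C=C/C(=O)O)cc1)c1ccc2[nH]nc(F)c2c1)C1CCC1`, has not yet been measured. It differs from compound 2 in one place: 5-chloro-3-cyanopyridin-2-yl in place of 2-chloro-4-(methylsulfonyl)phenyl on a double-bonded chain carbon bound to a double-bonded chain carbon and a saturated ring carbon. For the measured compounds named here, there is no pair of measured compounds that differ in just one place, so the size of such a step in this assay is unknown here. A step of moderate size is expected, somewhat upward from the low exposure of compound 2, but it could well fall within the scatter. Compound 3 is therefore estimated to give 350 ng.h/mL in this assay, within a range from 70 ng.h/mL to 1800 ng.h/mL. This estimate means an expected step of a 2.5-fold higher number from compound 2 to compound 3 (0.40 log units; beyond the scatter).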

Compound 3, area under the concentration-time curve: 250 ng.h/mL
Compound 3: middle estimate off by 1.4-fold (0.15 log units), on the high side, and the stated range covers the measured number.
By their numbers in this assay, from the lowest: compounds 2 and 3 (each within the scatter of the next); then compound 1.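

In this assay, putting 5-chloro-3-cyanopyridin-2-yl in place of 2-chloro-4-(methylsulfonyl)phenyl on a double-bonded chain carbon bound to a double-bonded chain carbon and a saturated ring carbon gives a 1.8-fold higher number from compound 2 to compound 3 (0.25 log units; within the scatter). For the compounds shown here, this is the first comparison in the set that involves a change in one place only, and it shows that a pyridine ring bearing a cyano group can replace a carbon-only ring bearing a methylsulfonyl group at this position without a change that can be told apart from the scatter of repeated measurements. Nothing measured here offers an explanation for this result.

The swap changes the ring atoms and the groups on the ring all at once, so a single step cannot show what each of these parts contributes on its own, or whether their separate contributions offset one another. Going by these compounds, it also remains open whether another group on this ring, such as an amine or a methoxy group, would move the number beyond the scatter.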